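Trimming a methoxy group on a pyrazole-linked chalcone

This account rests on a few compounds, and the source may have more. Where it says the series, first, only, none or still open, it means among the compounds named here.

Compound 1 `COc1cc(-c2cc(/C=C/C(=O)c3ccc(N)cc3)[nH]n2)cc(OC)c1OC` is tested in a functional assay on UO-31 cells (Homo sapiens) for inhibition, read by sulforhodamine B assay, with a stated time of 48 h (a higher number here means that more compound is tolerated, a lower number that less compound is tolerated), where compound 1 gives 6000 nM, the highest of the two plain numbers here. Compound 2 `COc1ccc(-c2cc(/C=C/C(=O)c3ccc(OC)c(OC)c3)[nH]n2)cc1` gives 5100 nM in this assay, and the two values sit within the scatter of each other. Compound 3 `COc1cc(-c2cc(/C=C/C(=O)c3ccc(Cl)c(Cl)c3)[nH]n2)cc(OC)c1OC` differs from compound 1 only at the carbonyl side, and in this assay compound 3 reaches only the limit of > 100000 nM. That change produced an at least 16-fold higher number from compound 1 to compound 3 (1.22 log units; beyond the scatter), and the value of compound 3 rests on (the limit of > 100000 nM in this assay, at which 1 of the 3 values shown sits).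

Compound 4 `COc1ccc(-c2cc(/C=C/C(=O)c3ccc(N)cc3)[nH]n2)cc1OC` is the next step from compound 1: hydrogen in place of methoxy on an aromatic carbon. Among the compounds with values here, no measured step touches this ring, so nothing measured bears directly on it; the step from compound 1 to compound 3 concerns the other ring. Compound 2, which carries fewer methoxy groups on this ring, stays close to compound 1, so no step beyond the scatter is expected, meaning a 1.2-fold higher number from compound 1 to compound 4 (0.07 log units; within the scatter). Compound 4 is expected to give about 7000 nM, between 3000 nM and 20000 nM.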

Compound 4, concentration lethal to 50% of the cells: 43200 nM
Beside the measured number, compound 4's estimate is 6.2-fold (0.79 log units) below it; measured number outside the range, above it.
By their numbers in this assay, from the lowest: compounds 2 and 1 (each within the scatter of the next); then compound 4. At a limit, above all of these: compound 3.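

Hydrogen in place of methoxy gives a 7.2-fold higher number from compound 1 to compound 4 (0.86 log units; beyond the scatter) in this assay, so less of compound 1 than of compound 4 is needed to reach the read-out. Within the data shown here, this is the first measured step on this ring, and it shows that a single methoxy group here moves the number beyond the scatter, so the carbonyl side is not the only part of the molecule that matters. Nothing measured here gives a reason for this step.

Still open, from the compounds shown here alone, is whether a hydroxyl, an ethoxy group or a fluorine at this position would keep the number close to that of compound 1 or move it towards that of compound 4. Also open, going by these compounds, is whether the same trimming would give a step of similar size with a different group on the carbonyl side.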